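Swapping a Cyanophenyl for a Methoxypyrazine: Stability Outlook

The compounds below may be only part of what the source reports. "The series", "measured", "known", "first", "only" and "open" are said of these compounds alone.

Measured so far:
compound 1 `COc1cc(OCc2cccc(-c3ccc(C#N)cc3)c2)c2cc(-c3cn4nc(OC)sc4n3)oc2c1` — > 2 h
compound 2 `CNC(=O)c1ccc(-c2nc(COc3cc(OC)cc4oc(-c5cn6nc(OC)sc6n5)cc34)cs2)cc1` — 0.983 h

In an ADME assay on microsomes from liver (Homo sapiens) for metabolic stability (a lower number here means that the compound disappears faster, a higher number that the compound lasts longer), compound 1 gives > 2 h, which is a limit of the assay and not a number. This places compound 1 at the limit of > 2 h in this assay, at which 1 of the 2 values shown sits. The change from compound 1 to the other measured compound is not a single step; in this assay compound 2 gives 0.983 h, and the two values are simply shown side by side.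

Compound 3 `COc1cc(OCc2cccc(-c3cnc(OC)cn3)c2)c2cc(-c3cn4nc(OC)sc4n3)oc2c1` is not yet measured. It differs from compound 1 in one place: 5-methoxypyrazin-2-yl in place of 4-cyanophenyl on an aromatic carbon. Going by the values given here, with no measured step of this kind to lean on, the size of the change is open. A modest shortening of the half-life is expected, and the step of an at least 1.3-fold lower number from compound 1 to compound 3 (0.12 log units; that floor lies within the scatter) carries that expectation for compound 3. For compound 3 the estimated half-life in this assay is 1.5 h, with a range from 0.7 h to 3 h.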

Compound 3, half-life: 1.48 h
Beside the measured number, compound 3's estimate is 1.0-fold (0.01 log units) above it; low and high end bracket the measured number.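

In this assay, going by these compounds alone, this is the first reading of a single change at this position: 5-methoxypyrazin-2-yl in place of 4-cyanophenyl gives an at least 1.3-fold lower number from compound 1 to compound 3 (0.13 log units; that floor lies within the scatter). The carbon-only ring and its nitrile give way to a ring with two hetero atoms and a methoxy group, and compound 3 gives 1.48 h, an actual number rather than a limit. From the compounds shown here alone, the true size of the step stays unknown, since the value of compound 1 is a limit: the limit of > 2 h in this assay, at which 1 of the 3 values shown sits.

Going by these compounds, it remains open which part of the swap matters, the ring nitrogens or the loss of the nitrile in favour of the methoxy group. A plain phenyl ring, or a pyrazine carrying an amine in place of the methoxy group, at this position would help to separate these parts.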